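The compounds below may be only part of what the source reports. "The series", "measured", "known", "first", "only" and "open" are said of these compounds alone.

Working notes on the series. Compound 1 `COc1ccc(NC(=O)C2=C(C)NC(=O)NC2c2ccccc2O)cc1` and compound 2 `COc1ccc(NC(=O)C2=C(C)NC(=S)NC2c2ccccc2O)cc1` share a core whose difference is not broken down here. In an ADME assay on Vero cells (Chlorocebus sabaeus) for cytotoxicity, read by sulforhodamine B assay, with a stated time of 3 days (on this read-out higher numbers stand for lower toxicity in this test and lower numbers for higher toxicity in this test), compound 1 gives 160 ug/mL, and compound 2 gives 246 ug/mL; these two values lie within the usual scatter of each other. Compound 3 `COc1ccc(NC(=O)C2=C(C)NC(=O)NC2c2cccc([N+](=O)[O-])c2)cc1` carries the change (3-nitrophenyl in place of 2-hydroxyphenyl on a saturated ring carbon), and in this assay compound 3 gives 64 ug/mL, giving the step of a 2.5-fold lower number from compound 1 to compound 3 (0.40 log units; beyond the scatter). Compound 4 `COc1ccc(NC(=O)C2=C(C)NC(=S)NC2c2cccc([N+](=O)[O-])c2)cc1` carries the same change on the core of compound 2, namely (3-nitrophenyl in place of 2-hydroxyphenyl on a saturated ring carbon). Among the measured compounds shown here, only one measured instance of this change exists. For the measured compounds named here, the step expected from compound 2 to compound 4 is a 2.5-fold lower number from compound 2 to compound 4 (0.39 log units; beyond the scatter), resting on the single measured step of a 2.5-fold lower number from compound 1 to compound 3 (0.40 log units; beyond the scatter). For compound 4 in this assay the estimated value is 100 ug/mL, with a range expected from 50 ug/mL to 200 ug/mL.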

Compound 4, half-maximal cytotoxic concentration: 80 ug/mL
The estimate for compound 4 lay 1.3-fold (0.10 log units) above the measured number; the range from low to high includes it.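

In this assay, 3-nitrophenyl in place of 2-hydroxyphenyl on a saturated ring carbon gives a 3.1-fold lower number from compound 2 to compound 4 (0.49 log units; beyond the scatter), and the size of this step carries over between the two cores: the same change on two cores in this assay, a 2.5-fold lower number (0.40 log units; beyond the scatter) from compound 1 to compound 3 and a 3.1-fold lower number (0.49 log units; beyond the scatter) from compound 2 to compound 4, 1.2-fold (0.09 log units) apart, within the scatter of two such steps. On both cores the change moves the number in the same direction, towards higher toxicity in this test, by amounts that cannot be told apart. This rests on two cores and one pair of groups, so it does not show that the change would carry to any other core, nor why the number falls.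

Going by these compounds, it remains open how much of the step belongs to the loss of 2-hydroxyphenyl and how much to the arrival of 3-nitrophenyl. An unsubstituted phenyl or a carboxyphenyl on that saturated ring carbon would help separate the two.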